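A few compounds are considered here, and "the series" means these few. Any claim that something is new, unique, unknown or untested is made for them only; others in the source may bear on it.

In a functional assay with Oryctolagus cuniculus as the target (a higher number here means a weaker inhibitor, a lower number a stronger inhibitor), compound 1 `COc1ccc(-c2nc(/N=C(\N)[N+]3(C)CCCCC3)sc2-c2ccc(OC)cc2)cc1` gives > 1000 nM, which is a limit of the assay and not a number. Compound 2 `COc1ccc(-c2nc(CN(C)C)sc2-c2ccc(OC)cc2)cc1` gives 96 nM. Compound 3 `COc1ccc(-c2nc(C(=O)N3CCOCC3)sc2-c2ccc(OC)cc2)cc1` gives < 10 nM, which is also a limit. Compound 3 is the strongest inhibitor of these three, as the steps of an at least 100-fold lower number from compound 1 to compound 3 (2.00 log units; beyond the scatter) and an at least 9.6-fold lower number from compound 2 to compound 3 (0.98 log units; beyond the scatter) show.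

Compound 4 `COc1ccc(-c2nc(/C=C/C(=O)O)sc2-c2ccc(OC)cc2)cc1` keeps the shared core and has 2-carboxyethenyl in place of (morpholin-4-yl)carbonyl on an aromatic carbon.

For the measured compounds named here, no measured compound carries 2-carboxyethenyl, so the measured steps guide only the size of the change. All were made at this same carbon, and they include an at least 10-fold lower number from compound 1 to compound 2 (1.01 log units; beyond the scatter). The read-out clearly responds strongly to the group placed there. Compound 3 already sits at the low limit, so a move to a higher number seems the more likely direction, though compound 4 could stay close. The expected change is an at least 3.0-fold higher number from compound 3 to compound 4 (0.47 log units; beyond the scatter). For compound 4, the estimated value is 30 nM, with an expected range from 5 nM to 200 nM.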

Compound 4, half-maximal inhibitory concentration: > 100 nM
Compound 4: a limit, no number; the forecaster's own chance of this, stated with the estimate: 25%; middle value at least 3.3-fold (0.52 log units) away from the limit.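

In this assay compound 4 gives > 100 nM, which is a limit and not a number. The change gives an at least 10-fold higher number from compound 3 to compound 4 (1.00 log units; beyond the scatter), so even two groups with no net charge are clearly separated at this carbon, and a neutral group here does not by itself keep the low number of compound 3. The step of an at least 1.0-fold higher number from compound 2 to compound 4 (0.01 log units; that floor lies within the scatter) is only a floor, so compound 4 cannot be ranked against compound 2, and the two limits leave its step from compound 1 unreadable.

This single change removes the morpholine ring and brings in a carboxylic acid on a two-carbon unsaturated chain, so the compounds shown cannot say which of these matters. A methyl ester of the same chain, or a morpholine amide on that chain, would help to separate them.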